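From 4-bromophenyl to 2-fluorophenyl on the amide side chain

The source may hold more compounds than are shown below. What is called first, only, known or untested is meant among the compounds shown, and "the series" means these compounds.

Measured values in a functional assay on U-266 cells (Homo sapiens) for antiproliferative activity, read by MTT assay, with a stated time of 72 h (on this read-out lower numbers stand for stronger inhibition and higher numbers for weaker inhibition), are as follows:
- compound 1 `C[C@H](NC(=O)/C(C#N)=C/c1cccc(Br)n1)c1ccc(Br)cc1` gives 1800 nM
- compound 2 `N#C/C(=C\c1cccc(Br)n1)C(=O)N[C@@H]1CCc2ccccc21` gives 2500 nM
- compound 3 `N#C/C(=C\c1cccc(Br)n1)C(=O)N[C@@H]1CCCc2ccccc21` gives 1900 nM

Compound 1 at 1800 nM cannot be separated from the other two compounds, as all three values lie within the usual scatter of each other. The next compound to be tested is compound 4 `C[C@H](NC(=O)/C(C#N)=C/c1cccc(Br)n1)c1ccccc1F`, which differs from compound 1 as follows: 2-fluorophenyl in place of 4-bromophenyl on a saturated chain carbon bound to an amide-type nitrogen and a saturated chain carbon, with 2-fluorophenyl in place of 4-bromophenyl on a saturated chain carbon bound to an amide-type nitrogen and a saturated chain carbon. For the measured compounds named here, no measured pair isolates this change. Compound 2 at 2500 nM and compound 3 at 1900 nM carry other groups on the amide nitrogen and still remain within the scatter of compound 1 at 1800 nM in this small set. In this assay, going by the values given here, the expected result is a 1.4-fold higher number from compound 1 to compound 4 (0.14 log units; within the scatter), a small estimated shift toward weaker inhibition that stays within the scatter, and no measured step supports its direction. For compound 4 the estimated value is 2500 nM, with an expected range from 1100 nM to 5500 nM at its ends.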

Compound 4, half-maximal inhibitory concentration: 2000 nM
Estimate against measurement, compound 4: 1.3-fold (0.10 log units) above; the range from low to high includes it.
By their numbers in this assay, from the lowest: compounds 1, 3, 4 and 2 (each within the scatter of the next).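

In this assay, 2-fluorophenyl in place of 4-bromophenyl on a saturated chain carbon bound to an amide-type nitrogen and a saturated chain carbon gives a 1.1-fold higher number from compound 1 to compound 4 (0.05 log units; within the scatter). For the compounds shown here, this is the first single-place step, and it shows that this exchange of aryl groups at this position produces no change that can be told from the scatter. Nothing measured here explains this result or bears on it.

The step exchanges the halogen and alters its place on the phenyl ring together, so it cannot separate the two, and 4-fluorophenyl or unsubstituted phenyl would be needed to do so. From the compounds shown here alone, whether an aminophenyl or carboxyphenyl group at this position would give a step beyond the scatter remains open.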